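Aryl replacement on the shared core: pyridin-4-yl for 2-chlorophenyl

The compounds below may be only part of what the source reports. "The series", "measured", "known", "first", "only" and "open" are said of these compounds alone.

Three analogues of one shared core have been measured in a functional assay on BJAB cells (Homo sapiens) for antiproliferative activity, with a stated time of 4 days; a higher number here means that more compound is needed for the effect, a lower number that less compound is needed. Compound 1 `COc1ccccc1-c1c(C)nn(-c2nc(-c3ccc(Cl)c(Cl)c3)c(SC(C)C)s2)c1C(=O)O` gives 14700 nM. Compound 2 `CNc1cc(-c2c(C)nn(-c3nc(-c4ccc(Cl)c(Cl)c4)c(SC(C)C)s3)c2C(=O)O)ccn1` gives 18000 nM. Compound 3 `Cc1nn(-c2nc(-c3ccc(Cl)c(Cl)c3)c(SC(C)C)s2)c(C(=O)O)c1-c1ccccc1Cl` gives 13100 nM. All three sit in one band: a 1.2-fold higher number from compound 1 to compound 2 (0.09 log units; within the scatter), a 1.1-fold lower number from compound 1 to compound 3 (0.05 log units; within the scatter), and a 1.4-fold lower number from compound 2 to compound 3 (0.14 log units; within the scatter), so compound 3 cannot be set apart from compound 1 or compound 2 on these numbers.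

Compound 4 `Cc1nn(-c2nc(-c3ccc(Cl)c(Cl)c3)c(SC(C)C)s2)c(C(=O)O)c1-c1ccncc1` is not yet measured. It differs from compound 3 in one place: pyridin-4-yl in place of 2-chlorophenyl on an aromatic carbon. The change again swaps the aryl group on this carbon of the shared core, as did the steps from compound 1 to compound 2 and from compound 2 to compound 3, and a pyridine ring already appears in compound 2. None of the three measured steps left the scatter, the nitrogen-containing ring in compound 2 included, so no step beyond the scatter is expected in this assay for the change to compound 4.

The value of compound 4 is therefore expected to lie near that of compound 3, at about 14000 nM, estimated between 7000 nM and 30000 nM, which means an expected step of a 1.1-fold higher number from compound 3 to compound 4 (0.03 log units; within the scatter).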

Compound 4, half-maximal effective concentration: 5900 nM
The estimate for compound 4 lay 2.4-fold (0.38 log units) above the measured number; measured number outside the range, below it.
By their numbers in this assay, from the lowest: compound 4; then compounds 3, 1 and 2 (each within the scatter of the next).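

In this assay, this aromatic carbon, next to the ring atom that bears a carboxy group and next to the ring atom that bears a methyl group, gives its first steps beyond the scatter: pyridin-4-yl in place of 2-chlorophenyl gives the first step (a 2.2-fold lower number from compound 3 to compound 4 (0.35 log units; beyond the scatter)), and pyridin-4-yl in place of 2-methoxyphenyl gives the second (a 2.5-fold lower number from compound 1 to compound 4 (0.40 log units; beyond the scatter)). A pyridine ring as such does not set the level, since compound 2 also carries one yet stays within the scatter of compound 1 and compound 3, whereas hydrogen in place of methylamino on that ring gives the largest step in the set (a 3.1-fold lower number from compound 2 to compound 4 (0.48 log units; beyond the scatter)). The series therefore tolerates aryl exchange at this carbon without being flat to it, although nothing available here explains the gain.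

Unsubstituted phenyl at this carbon would show whether the step tracks the ring nitrogen or the loss of the substituents on the aryl ring, a distinction the present compounds cannot make. Also open, from the compounds shown here alone, are pyridin-3-yl, with the ring nitrogen placed elsewhere, and whether the step survives with an amide in place of the carboxylic acid.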